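This account rests on a few compounds, and the source may have more. Where it says the series, first, only, none or still open, it means among the compounds named here.

In a functional assay on PC-3 cells (Homo sapiens), read by MTT assay, with a stated time of 48 h; on this read-out higher numbers stand for weaker inhibition and lower numbers for stronger inhibition:
compound 1 `CCn1c(C(=O)NCCCN(C)C)ccc1C(CC)(CC)c1ccc(OCC(O)C(C)(C)C)c(C)c1`: 3100 nM
compound 2 `CCN(CC)CCCNC(=O)c1ccc(C(CC)(CC)c2ccc(OCC(O)C(C)(C)C)c(C)c2)n1CC`: 2500 nM
compound 3 `CCn1c(C(=O)N(CCC#N)CCC#N)ccc1C(CC)(CC)c1ccc(OCC(O)C(C)(C)C)c(C)c1`: 7800 nM

Of these three, compound 3 gives the highest number, 7800 nM, which makes it the weakest inhibitor in this small set. Compound 4 `C#CC(C)OC(=O)c1ccc(C(CC)(CC)c2ccc(OCC(O)C(C)(C)C)c(C)c2)n1CC` keeps the shared core of compound 3 and differs only in the group on the carbonyl carbon: a group of 5 heavy atoms (4 carbon, 1 oxygen; no ring) in place of a group of 9 heavy atoms (6 carbon, 3 nitrogen; no ring), on a carbonyl carbon. Going by the values given here, the group that enters is (1-methylprop-2-yn-1-yl)oxy, and no measured compound carries it, so the data offer no direct precedent.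

The closest evidence comes from the other changes at this carbonyl carbon. These moved the number only modestly: a 2.5-fold higher number from compound 1 to compound 3 (0.40 log units; beyond the scatter) and a 3.1-fold higher number from compound 2 to compound 3 (0.49 log units; beyond the scatter). The smaller swap of dimethylamino for diethylamino gave a 1.2-fold lower number from compound 1 to compound 2 (0.09 log units; within the scatter), which lies within the scatter. None of these steps shows which way the new group should push the number. Among the compounds with values here, with modest steps as the only guide, no change beyond the scatter is expected in this assay, although a modest move in either direction would not be surprising. The expected step is a 1.1-fold lower number from compound 3 to compound 4 (0.05 log units; within the scatter). For compound 4 the estimated value is 7000 nM, with an expected range from 3000 nM to 16000 nM.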

Compound 4, half-maximal inhibitory concentration: 38200 nM
For compound 4 the middle estimate is 5.5-fold (0.74 log units) below the measured one; the whole stated range lies below it.
By their numbers in this assay, from the lowest: compounds 2 and 1 (each within the scatter of the next); then compound 3; then compound 4.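

In this assay, placing (1-methylprop-2-yn-1-yl)oxy on the carbonyl carbon produces the biggest changes seen at this position, with a 15-fold higher number from compound 2 to compound 4 (1.18 log units; beyond the scatter) and a 12-fold higher number from compound 1 to compound 4 (1.09 log units; beyond the scatter) both counting as large. Going by these compounds alone, the position is therefore more sensitive than the earlier compounds suggested, and compound 4 is the weakest inhibitor of the four. The new group also stands well apart from the other group without hydrogen-bond donors, with a 4.9-fold higher number from compound 3 to compound 4 (0.69 log units; beyond the scatter) even though neither group carries a donor, so the absence of donors does not by itself set compound 3 and compound 4 on the same level.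

The compounds shown do not separate the oxygen link to the carbonyl carbon from the triple bond at the end of the new group, and an ethoxy group or a (1-methylprop-2-yn-1-yl)amino group at the same place would be the comparisons that pull these two features apart. No measurement offered here gives a reason for the size of these steps.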